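The source may report more compounds than this note shows. Statements on the series, on what has been measured and on what is new or still open speak of the compounds shown alone.

Compound 2, `CCN(CC)Cc1cc2c(N)nc(-c3ccco3)nc2s1`, gives 2130 nM in an assay on CHO-K1 cells for antagonist activity at adenosine receptor A1 (Homo sapiens), read by a beta-galactosidase reporter, with stated times of 15 min and 6 h; a lower number here means a stronger inhibitor, a higher number a weaker inhibitor. Its only companion so far is compound 1, `CN(C)Cc1cc2c(N)nc(-c3ccco3)nc2s1`, which in this assay gives 3550 nM; the step of a 1.7-fold lower number from compound 1 to compound 2 (0.22 log units; within the scatter) lies within the scatter, so the two numbers cannot be told apart.

Compound 3, `Nc1nc(-c2ccco2)nc2sc(CNC3CCCCC3)cc12`, is the next member of this series. Relative to compound 2 the change is cyclohexylamino in place of diethylamino on a saturated chain carbon bound to an aromatic carbon. For the measured compounds named here, the one step already measured, a 1.7-fold lower number from compound 1 to compound 2 (0.22 log units; within the scatter), also swapped the groups on the amine nitrogen and produced no shift beyond the scatter; it is the only step that bears on the present change. Going by the values given here, no measured step brings in a ring or a hydrogen-bond donor at this place, so nothing in the data points to a large shift in either direction. Compound 3 is therefore expected to stay close to compound 2, with the estimated step of a 1.2-fold lower number from compound 2 to compound 3 (0.07 log units; within the scatter) and an estimated value of 1800 nM, within a range from 600 nM to 5500 nM.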

Compound 3, inhibition constant: 2480 nM
Beside the measured number, compound 3's estimate is 1.4-fold (0.14 log units) below it, and the stated range covers the measured number.
By their numbers in this assay, from the lowest: compounds 2, 3 and 1 (each within the scatter of the next).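

In this assay, cyclohexylamino in place of diethylamino gives a 1.2-fold higher number from compound 2 to compound 3 (0.07 log units; within the scatter), and cyclohexylamino in place of dimethylamino gives a 1.4-fold lower number from compound 1 to compound 3 (0.16 log units; within the scatter). The earlier pair only swapped one open-chain amine for another, whereas these steps bring in a six-membered non-aromatic ring and a hydrogen-bond donor on the saturated chain carbon bound to an aromatic carbon, and still no shift can be told from the scatter. No available evidence bears on why these three amines cannot be told apart.

On these data alone, all three compounds carry an amine at this place, so it remains open whether any group there can move the number beyond the scatter. A carboxylic acid, an amide or a hydroxyl in place of the amine, or a phenyl group on its nitrogen, would test this.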